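The source may report more compounds than this note shows. Statements on the series, on what has been measured and on what is new or still open speak of the compounds shown alone.

Working notes on the series.

Among the compounds with values here, compound 2 `O=C(COCc1ccccc1)N1CCN(c2ccc(Cl)cc2Cl)CC1` gives 450 mL.min-1.g-1 in an in vitro ADME assay on microsomes from liver (Homo sapiens) for metabolic stability (a higher number here means faster removal of the compound, a lower number slower removal), the highest of the three numbers so far. Compound 1 `O=C(COCc1ccccc1)N1CCN(c2ccc(Cl)cc2)CC1` gives 290 mL.min-1.g-1, and the step of a 1.6-fold higher number from compound 1 to compound 2 (0.19 log units; within the scatter) is within the scatter, so the two are not ordered. Compound 3 `O=C(COCc1ccccc1)N1CCN(c2cc(Cl)ccn2)CC1` gives 130 mL.min-1.g-1; the steps of a 2.2-fold lower number from compound 1 to compound 3 (0.35 log units; beyond the scatter) and a 3.5-fold lower number from compound 2 to compound 3 (0.54 log units; beyond the scatter) are modest but beyond the scatter.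

Compound 4 `N#Cc1ccc(COCC(=O)N2CCN(c3ccc(Cl)cc3Cl)CC2)s1` differs from compound 2 at the other end of the molecule: 5-cyanothiophen-2-yl in place of phenyl on a saturated chain carbon bound to an oxygen on a saturated carbon. Within the data shown here, none of the measured steps touches this position; all three concern the group on the amine nitrogen in the ring, and they are modest in size. Among the measured compounds shown here, no measured step therefore bears directly on the change to compound 4, and the expectation rests only on the number for compound 2. The estimated step of a 1.2-fold lower number from compound 2 to compound 4 (0.07 log units; within the scatter) is expected to lie within the scatter, with no direction claimed. Compound 4 is estimated at 380 mL.min-1.g-1, with a range from 150 mL.min-1.g-1 to 900 mL.min-1.g-1.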

Compound 4, intrinsic clearance in microsomes: 110 mL.min-1.g-1
For compound 4 the middle estimate is 3.5-fold (0.54 log units) above the measured one, outside the stated range (below it).
By their numbers in this assay, from the lowest: compounds 4 and 3 (each within the scatter of the next); then compounds 1 and 2 (each within the scatter of the next).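

The other end of the molecule also moves the number in this assay: 5-cyanothiophen-2-yl in place of phenyl on a saturated chain carbon bound to an oxygen on a saturated carbon gives a 4.1-fold lower number from compound 2 to compound 4 (0.61 log units; beyond the scatter). Within the data shown here, the earlier steps all concern the group on the amine nitrogen in the ring, so this is the first reading at this position. The change alters the ring and adds a nitrile together, so the step belongs to the whole group and cannot be divided between those two parts, and no measurement on hand explains it.

As far as these compounds go, whether a plain thiophen-2-yl or a phenyl carrying a nitrile would give a similar step remains open. So does whether the same exchange would hold on compound 3, with its 4-chloropyridin-2-yl group.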